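The source may report more compounds than this note shows. Statements on the series, on what has been measured and on what is new or still open speak of the compounds shown alone.

In an ADME assay on MT2 cells (Homo sapiens) for cytotoxicity, read by XTT assay, with a stated time of 4 days (on this read-out lower numbers stand for higher toxicity in this test and higher numbers for lower toxicity in this test), compound 1 (`Cc1cc(/C=C/C#N)cc(C)c1Oc1ccc([N+](=O)[O-])c(Nc2ccc(C#N)cc2)n1`) reads > 100000 nM as a limit of the assay and not a number. Going by the values given here, compound 2 (`Cc1cc(/C=C/C(=O)O)cc(C)c1Oc1ccc(N)c(Nc2ccc(C#N)cc2)n1`) gives 15700 nM and so holds the only true number. Compound 3 (`Cc1cc(/C=C/C#N)cc(C)c1Oc1ccc(N)c(Nc2ccc(C#N)cc2)n1`) departs from compound 2 in one place (cyano in place of carboxy on a double-bonded chain carbon bound to a double-bonded chain carbon) with cyano in place of carboxy on a double-bonded chain carbon bound to a double-bonded chain carbon. Among the compounds with values here, no measured step speaks to this exchange, so the expectation rests on compound 2 at 15700 nM alone. A modest move toward lower numbers in this assay is expected, meaning somewhat higher toxicity, and it may barely clear the usual scatter. The expected change is a 2.2-fold lower number from compound 2 to compound 3 (0.35 log units; beyond the scatter) by this estimate. Compound 3 is expected at 7000 nM with an estimated range from 1800 nM to 30000 nM around that middle.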

Compound 3, half-maximal cytotoxic concentration: 5630 nM
For compound 3 the middle estimate is 1.2-fold (0.09 log units) above the measured one, within the range that was stated.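

In this assay, the exchange of carboxy for cyano on a double-bonded chain carbon bound to a double-bonded chain carbon now has a measured size, with a 2.8-fold lower number from compound 2 to compound 3 (0.45 log units; beyond the scatter) in the direction of higher toxicity in this test. On the same core, amino in place of nitro on an aromatic carbon gives an at least 17-fold lower number from compound 1 to compound 3 (1.24 log units; beyond the scatter) and is the larger of the two steps. Compound 1 stands at a limit of the assay and not a number, so this second step fixes only the least size of the change: the limit of > 100000 nM in this assay, at which 1 of the 3 values shown sits.

Each exchange rests on a single pair of compounds, so neither can be read as a pattern beyond them. As far as these compounds go, how an ester, an amide or a longer chain would read at the place of the cyano group stays open.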